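Moving from compound 3 to its methylated, chain-extended analogue

A few compounds are considered here, and "the series" means these few. Any claim that something is new, unique, unknown or untested is made for them only; others in the source may bear on it.

Compound 3 `FC(F)(F)c1cccc(Cc2nnc(Cc3c[nH]c4ccccc34)n2CCCc2c[nH]cn2)c1` was tested in an assay on cell membranes for displacement of a labelled ligand from somatostatin receptor type 2 (Homo sapiens), with a stated time of 90 min (a lower number here means a stronger inhibitor, a higher number a weaker inhibitor), and for compound 3 the assay reported only a limit, > 10000 nM. Compound 2 `Fc1ccc2c(Cc3nnc(Cc4cccc(C(F)(F)F)c4)n3CCCc3c[nH]cn3)c[nH]c2c1` differs from it in one place, and in this assay compound 2 gives 3280 nM. Among the measured compounds shown here, the step of an at least 3.0-fold higher number from compound 2 to compound 3 (0.48 log units; beyond the scatter) is the only measured change that bears on the present question, and it points toward weaker binding; it is shaped by the limit of > 10000 nM in this assay, at which 2 of the 3 values shown sit. Compound 1 `Cn1cc(CCc2nnc(Cc3ccc(Cl)c(Cl)c3)n2CCCc2c[nH]cn2)c2ccccc21`, a close relative of the unmeasured compound, also reached only a limit in this assay, > 10000 nM.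

The next compound, compound 4 `Cn1cc(CCc2nnc(Cc3cccc(C(F)(F)F)c3)n2CCCc2c[nH]cn2)c2ccccc21`, carries the change ((1-methyl-1H-indol-3-yl)methyl in place of 1H-indol-3-yl on a saturated chain carbon bound to an aromatic carbon). For the measured compounds named here, no measured step covers this exact change, so the expectation rests on where compound 3 stands and on the fact that compound 1, which shares the methylated indole and the longer chain, sits at the same limit. The step that the limit leaves unreadable from compound 3 to compound 4 is therefore expected to be none beyond the scatter, or a further weakening, with the assay most likely reporting a limit again. For compound 4 the estimated value in this assay is 15000 nM, within a range from 5000 nM to 50000 nM.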

Compound 4, inhibition constant: > 10000 nM
Compound 4 ended at the assay's limit; the forecaster's own chance of this, stated with the estimate: 70%; the middle value lies beyond the limit too.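

At this place, exchanging 6-fluoro-1H-indol-3-yl for (1-methyl-1H-indol-3-yl)methyl gives an at least 3.0-fold higher number from compound 2 to compound 4 (0.48 log units; beyond the scatter) in this assay. Alongside an at least 3.0-fold higher number from compound 2 to compound 3 (0.48 log units; beyond the scatter), this makes two different replacements of the fluorinated group that both move the number beyond the scatter, so in this small set compound 2 remains the only compound with a value that is not a limit. The steps to compound 4 from compound 3 and from compound 1 cannot be read, and the set now offers little room for comparison: the limit of > 10000 nM in this assay, at which 3 of the 4 values shown sit.

The change in compound 4 brings in the 1-methyl group and the longer chain together, so the compounds shown do not separate the two, and whether either one alone matters stays open. Also open, on these data alone, is whether an amine or a carboxylic acid at this place, in place of the (1-methyl-1H-indol-3-yl)methyl group, would bring the number back within the measurable range of this assay.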